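This account rests on a few compounds, and the source may have more. Where it says the series, first, only, none or still open, it means among the compounds named here.

Measured in a functional assay (Saphenous vein) for inhibition, with Oryctolagus cuniculus as the target; on this read-out higher numbers stand for weaker binding and lower numbers for tighter binding:
- compound 1 `O=C(O)CCc1cc(Cc2cccnc2)cc2c1CCC(NS(=O)(=O)c1ccc(Cl)cc1)C2`: 0.2 nM
- compound 2 `O=C(O)CCC/C=C\c1c(Cc2cccnc2)ccc2c1CCC(NS(=O)(=O)c1ccc(Cl)cc1)C2`: 0.2 nM
- compound 3 `O=C(O)CCC/C=C/c1cc(Cc2cccnc2)cc2c1CCC(NS(=O)(=O)c1ccc(Cl)cc1)C2`: 2 nM

Compound 3, at 2 nM, has the highest number of the three, so it binds least tightly. Compounds 1 and 2 both lie below it, by a gap beyond the usual scatter.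

Compound 4 `O=C(O)CCC/C=C\c1cc(Cc2cccnc2)cc2c1CCC(NS(=O)(=O)c1ccc(Cl)cc1)C2` is a close relative of compound 3: the two compounds have the same atoms and bonds; at least one stereo element is drawn with a configuration in one of them and without one in the other: 1 of 2 stereo elements differ; a double bond is drawn E in compound 3 and Z in compound 4. Within the data shown here, the double bond is therefore the only thing that changes.

Among the measured compounds shown here, only one measured step involves compound 3, a 10-fold higher number from compound 1 to compound 3 (1.00 log units; beyond the scatter). For the measured compounds named here, it is a modest step, and it replaces the 2-carboxyethyl group with the 5-carboxypent-1-en-1-yl group, so it says nothing directly about E against Z. No measured pair isolates that change. The nearest hint is compound 2, whose double bond is also drawn Z and which gives 0.2 nM. That is only a loose guide, so a moderate move towards a lower number is expected, with wide uncertainty.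

The expected change is a 3.3-fold lower number from compound 3 to compound 4 (0.52 log units; beyond the scatter).

For compound 4 the estimated value is 0.6 nM, with an expected range from 0.1 nM to 3 nM.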

Compound 4, dissociation constant: 2.51 nM
Compound 4: middle estimate off by 4.2-fold (0.62 log units), on the low side, within the range that was stated.
By their numbers in this assay, from the lowest: compounds 1 and 2 (each within the scatter of the next); then compounds 3 and 4 (each within the scatter of the next).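

In this assay the geometry of the double bond in the 5-carboxypent-1-en-1-yl chain makes no clear difference at this position, since a 1.3-fold higher number from compound 3 to compound 4 (0.10 log units; within the scatter) stays within the scatter. Replacing 2-carboxyethyl with this chain now has a known result for both double-bond forms, with the Z form giving a 13-fold higher number from compound 1 to compound 4 (1.10 log units; beyond the scatter) and the E form giving a 10-fold higher number from compound 1 to compound 3 (1.00 log units; beyond the scatter), so the rise from compound 1 appears with either geometry. The reading of E against Z carries one caution: the fact that one of compounds 3 and 4 is drawn with a defined configuration and the other without, at the place where they differ.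

The compounds shown leave open how a fully saturated 5-carboxypentyl chain would compare with these two unsaturated chains. They also leave open whether a tetrazole or an amide in place of the carboxylic acid at the end of the chain would keep these values.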